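Aryl ketone swap on the benzyl hydroxamate core

The source may hold more compounds than are shown below. What is called first, only, known or untested is meant among the compounds shown, and "the series" means these compounds.

The shared core carries an aryl ketone on one side and a hydroxamic acid on the other. Compound 1 `COc1ccc(C(=O)c2ccc3c(ccn3Cc3ccc(C(=O)NO)cc3)c2)cc1OC` gives 18900 nM in an assay on isolated protein for inhibition of polyamine deacetylase HDAC10 (Homo sapiens) (a lower number here means a stronger inhibitor, a higher number a weaker inhibitor), the highest of the two numbers recorded. The nearest neighbour is compound 3 `Cc1ccc(C(=O)c2ccc3c(ccn3S(=O)(=O)c3cccc(/C=C/C(=O)NO)c3)c2)cc1`, which in this assay gives 9100 nM. Compound 2 `COc1cc(C(=O)c2ccc3c(ccn3S(=O)(=O)c3cccc(/C=C/C(=O)NO)c3)c2)cc(OC)c1OC` in this assay reaches only the limit > 100000 nM, a limit of the assay and not a number. the limit of > 100000 nM in this assay, at which 1 of the 3 values shown sits, marks that limit.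

The step from compound 2 to compound 3 replaced 3,4,5-trimethoxyphenyl with 4-methylphenyl on the carbonyl carbon and gave an at least 10-fold lower number from compound 2 to compound 3 (1.04 log units; beyond the scatter).

Compound 4 `Cc1ccc(C(=O)c2ccc3c(ccn3Cc3ccc(C(=O)NO)cc3)c2)cc1` is not yet measured in this assay. It arises from compound 1 by 4-methylphenyl in place of 3,4-dimethoxyphenyl on a carbonyl carbon. Among the compounds with values here, the only measured step that bears on it is the one from compound 2 to compound 3, which ran in the same direction on the same carbonyl carbon, though starting from a different methoxy count and on a different linker; a smaller shift of the same sign is therefore expected, about a 3.8-fold lower number from compound 1 to compound 4 (0.58 log units; beyond the scatter).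

For compound 4 the expected value in this assay is 5000 nM, with a range of 1500 nM to 16000 nM.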

Compound 4, half-maximal inhibitory concentration: > 100000 nM
Compound 4 ended at the assay's limit; the forecaster's own chance of this, stated with the estimate: 5%; middle value at least 20-fold (1.30 log units) away from the limit.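

On the core of compound 1, the group on the carbonyl carbon also moves the result in this assay, and here the change to 4-methylphenyl runs the opposite way: an at least 5.2-fold higher number from compound 1 to compound 4 (0.72 log units; beyond the scatter). On the other linker, 4-methylphenyl in place of 3,4,5-trimethoxyphenyl gave an at least 10-fold lower number from compound 2 to compound 3 (1.04 log units; beyond the scatter), so the direction of a swap to 4-methylphenyl at this carbonyl carbon does not hold across the two linkers, although the departing groups also differ. Compound 4 stands at a limit of the assay and not at a number, so its step gives only a bound, and the series now has two such entries: the limit of > 100000 nM in this assay, at which 2 of the 4 values shown sit.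

As far as these compounds go, it remains open whether one methoxy group on the aryl ring is enough on the core of compound 1, as a 4-methoxyphenyl ketone would show. A 4-aminophenyl ketone on each linker would test whether the reversal extends beyond these groups.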